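The compounds below may be only part of what the source reports. "The series", "measured", "known", "first", "only" and "open" are said of these compounds alone.

In a functional assay on A549 cells (Homo sapiens) for antiproliferative activity, read by MTT assay, with a stated time of 72 h (on this read-out lower numbers stand for stronger inhibition and higher numbers for weaker inhibition), compound 1 `Cc1nc(C)c(/C=C/C(=O)/C=C/c2ccccc2O)nc1C` gives 4780 nM. Compound 2 `Cc1nc(C)c(/C=C/C(=O)/C=C/c2ccc(F)cc2)nc1C` gives 5900 nM, level with it, while compound 3 `Cc1nc(C)c(/C=C/C(=O)/C=C/c2ccc(Cl)cc2)nc1C` gives 15800 nM. Compound 1 therefore stands at the low, more active end of this small set, sharing that place with compound 2. Compound 4 `Cc1nc(C)c(/C=C/C(=O)/C=C/c2ccccc2[N+](=O)[O-])nc1C` has not been measured yet. Within the data shown here, its one change from compound 1 is nitro in place of hydroxy on an aromatic carbon, ortho to a large group. Among the measured compounds shown here, no measured compound carries a nitro, so the guidance is only indirect. Two measured steps also replace the 2-hydroxyphenyl group: a 1.2-fold higher number from compound 1 to compound 2 (0.09 log units; within the scatter), and a 3.3-fold higher number from compound 1 to compound 3 (0.52 log units; beyond the scatter). A third, a 2.7-fold higher number from compound 2 to compound 3 (0.43 log units; beyond the scatter), shows that swapping one group on an aromatic carbon can matter here. Neither step away from compound 1 lowered the number, so a small rise is expected in this assay, perhaps none beyond the scatter. The expected step is a 1.7-fold higher number from compound 1 to compound 4 (0.22 log units; within the scatter). For compound 4 the estimated value is 8000 nM, with a likely range from 3000 nM to 22000 nM.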

Compound 4, half-maximal inhibitory concentration: 17300 nM
The estimate for compound 4 lay 2.2-fold (0.33 log units) below the measured number; measured number inside the range.
By their numbers in this assay, from the lowest: compounds 1 and 2 (each within the scatter of the next); then compounds 3 and 4 (each within the scatter of the next).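

In this assay, changing only the group on this aromatic carbon, ortho to a large group, gives a 3.6-fold higher number from compound 1 to compound 4 (0.56 log units; beyond the scatter). Among these compounds, compounds 2 and 3 also change the position of the group on the ring, so this is the first step showing that a swap at this same carbon alone can move the number beyond the scatter, leaving compound 4 at 17300 nM within the scatter of compound 3. No measurement shown here explains this rise.

From the compounds shown here alone, it remains open whether the hydroxy itself matters at this carbon, or whether an amine, a methoxy group or a fluoro there would keep the number near that of compound 1. A 4-nitrophenyl group would also show whether nitro gives the same result at the position held by fluoro and chloro in compounds 2 and 3.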